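Swapping a Hydroxy Side Group for Two Methyls

The compounds below may be only part of what the source reports. "The series", "measured", "known", "first", "only" and "open" are said of these compounds alone.

Three compounds share a core built around a phenylethynylbenzamide joined to a hydroxamic acid, and differ only in the group carried on the saturated chain carbon. Compound 1 `C#CCNC(=O)C[C@H](NC(=O)c1ccc(C#Cc2ccccc2)cc1)C(=O)NO` carries a propargylcarbamoyl there; in a physicochemical assay for lipophilicity (a lower number here means a more polar compound, a higher number a more lipophilic compound), compound 1 gives 3. Compound 2 `O=C(N[C@@H](CO)C(=O)NO)c1ccc(C#Cc2ccccc2)cc1` carries a hydroxy instead, and in this assay compound 2 gives 2. Compound 3 `CS(=O)(=O)C[C@H](NC(=O)c1ccc(C#Cc2ccccc2)cc1)C(=O)NO` carries a methylsulfonyl, and in this assay compound 3 gives 2. The measured steps are a number 1.00 log units lower from compound 1 to compound 2 (beyond the scatter) and a number 1.00 log units lower from compound 1 to compound 3 (beyond the scatter), while no change at the digits printed from compound 2 to compound 3 (within the scatter). Among the measured compounds shown here, compound 2 thus stands level with compound 3 at the digits printed, the two together at the low end of the set, with compound 1 the only compound clearly apart from them.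

Compound 4 `CC(C)(NC(=O)c1ccc(C#Cc2ccccc2)cc1)C(=O)NO` has not yet been measured in this assay. Relative to compound 2, the change is a group of 7 heavy atoms (4 carbon, 1 nitrogen, 2 oxygen; no ring) in place of a group of 7 heavy atoms (3 carbon, 1 nitrogen, 3 oxygen; no ring), on an amide-type nitrogen: the hydroxy is among what leaves, and what enters holds one more carbon, one fewer oxygen, and one fewer hydrogen-bond donor and acceptor. For the measured compounds named here, no measured step removes a hydroxy in this way, so the two known steps give only the scale of a one-group change here. Compound 4 is expected to read higher than compound 2, by an estimated a number 0.80 log units higher from compound 2 to compound 4 (beyond the scatter), giving an estimate of 2.8 with a range from 2.3 to 3.4.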

Compound 4, distribution coefficient: 3
Beside the measured number, compound 4's estimate is 0.20 log units below it; the range from low to high includes it.
By their numbers in this assay, from the lowest: compounds 2 and 3 (each within the scatter of the next); then compounds 1 and 4 (each within the scatter of the next).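

The earlier compounds shown here showed that a propargylcarbamoyl on this chain carbon reads apart from a hydroxy or a methylsulfonyl, but each of those side groups holds oxygen. Compound 4 shows that no such side group is needed for the higher reading: with 1-(hydroxycarbamoyl)-1-methylethyl on the amide-type nitrogen, the result in this assay is a number 1.00 log units higher from compound 2 to compound 4 (beyond the scatter), which brings two plain methyls to the same printed level as the larger propargylcarbamoyl, with compound 1 at 3 and compound 4 at 3. No measurement here accounts for this step, and the swap is a bundle in which the hydroxy leaves, a carbon is gained, the hydrogen-bond donor and acceptor counts fall and the defined stereocentre goes.

The compounds shown leave open how much of the step belongs to each part of that bundle: none of them carries a single methyl on this carbon in place of the hydroxy-bearing group. They also leave open how an amine, a carboxylic acid or a longer chain such as ethyl would read at this place in this assay.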